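This account rests on a few compounds, and the source may have more. Where it says the series, first, only, none or still open, it means among the compounds named here.

Measured in an ADME assay on HEK293 cells (Homo sapiens) for cytotoxicity, read by MTT assay, with a stated time of 24 h; a lower number here means a stronger inhibitor, a higher number a weaker inhibitor:
Compound 1 `CN1CCN(CCCNc2nc3cc([N+](=O)[O-])ccc3nc2NCc2ccc(C(F)(F)F)cc2)CC1`: 9.53 ug/mL
Compound 2 `CN(C)CCCNc1nc2cc([N+](=O)[O-])ccc2nc1NCc1ccccc1`: 2.74 ug/mL
Compound 3 `CN(C)CCCNc1nc2cc([N+](=O)[O-])ccc2nc1NCc1ccccc1Br`: 51.9 ug/mL

Of these three, compound 3 gives the highest number, 51.9 ug/mL, which makes it the weakest inhibitor of the group. A further compound, compound 4 `CN(C)CCCNc1nc2cc([N+](=O)[O-])ccc2nc1NCc1ccc(Cl)c(C(F)(F)F)c1`, has not yet been measured. It keeps the rest of compound 3 and changes a single group: 4-chloro-3-(trifluoromethyl)phenyl in place of 2-bromophenyl on a saturated chain carbon bound to a nitrogen on an aromatic ring. In words, 4-chloro-3-(trifluoromethyl)phenyl stands in place of 2-bromophenyl on a saturated chain carbon bound to a nitrogen on an aromatic ring.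

Among the compounds with values here, only one measured step bears directly on this change: a 19-fold higher number from compound 2 to compound 3 (1.28 log units; beyond the scatter), seen when bromo replaced hydrogen on an aromatic carbon. Compound 4 has no bromo, so part of that large step may be reversed. Within the data shown here, that remains uncertain, since no step has been measured for the groups that enter. Compound 1 also carries a trifluoromethyl group and gives 9.53 ug/mL, but it differs elsewhere too, so it offers only a loose guide.

In this assay, a clear move to a lower number is therefore expected, though a smaller one than the bromo step. The estimated change is a 5.2-fold lower number from compound 3 to compound 4 (0.72 log units; beyond the scatter). For compound 4 the expected value is 10 ug/mL, with an estimated range from 2.5 ug/mL to 45 ug/mL.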

Compound 4, half-maximal inhibitory concentration: 3.26 ug/mL
The estimate for compound 4 lay 3.1-fold (0.49 log units) above the measured number, within the range that was stated.
By their numbers in this assay, from the lowest: compounds 2 and 4 (each within the scatter of the next); then compound 1; then compound 3.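

In this assay, replacing 2-bromophenyl with 4-chloro-3-(trifluoromethyl)phenyl gives a 16-fold lower number from compound 3 to compound 4 (1.20 log units; beyond the scatter) and so undoes almost all of the rise that came with bromo. The plain phenyl comparison gives a 1.2-fold higher number from compound 2 to compound 4 (0.08 log units; within the scatter), a step within the scatter, so the larger ring of 11 heavy atoms, against 7 for 2-bromophenyl, carries both chloro and trifluoromethyl and still cannot be told apart from an unsubstituted ring at this position. The high number of compound 3 is therefore not shared by the other halogen-bearing ring here, but nothing measured explains why these rings differ so sharply.

Compound 3 and compound 4 differ in both the atoms on the ring and where they sit, so these compounds cannot show whether the high number belongs to bromo itself or to its place in 2-bromophenyl. From the compounds shown here alone, it also remains open how this assay would respond to a ring bearing a methoxy group or a nitrile, or to a ring carrying chloro or trifluoromethyl alone.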